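A few compounds are considered here, and "the series" means these few. Any claim that something is new, unique, unknown or untested is made for them only; others in the source may bear on it.

Measured so far in an in vitro functional assay on cells for agonist activity at Bombesin receptor subtype-3 (Mus musculus), read by luminescence and calcium flux; on this read-out lower numbers stand for an effect already at smaller amounts and higher numbers for an effect only at larger amounts of compound:
compound 1, `CCCCc1cnc(C(C)Cc2ccc(-c3ccccc3C(=O)O)cc2)[nH]1`: 184 nM
compound 2, `CCCCc1cnc(C(CCC)Cc2ccc(-c3ccccc3C(=O)O)cc2)[nH]1`: 165 nM
compound 3, `Cc1ccccc1Cc1cnc(CCc2ccc(-c3ccccc3C(=O)O)cc2)[nH]1`: 9.3 nM

Compound 3 stands lowest of the three, well beyond the scatter from compound 1 and compound 2, which sit close to each other. Compound 4, `COc1ccc(Cc2cnc(CCc3ccc(-c4ccccc4C(=O)O)cc3)[nH]2)cc1`, differs from compound 3 in one place: 4-methoxyphenyl in place of 2-methylphenyl on a saturated chain carbon bound to an aromatic carbon. Going by the values given here, the only measured single step, a 1.1-fold lower number from compound 1 to compound 2 (0.05 log units; within the scatter), changes a saturated chain carbon rather than the aryl group of a benzyl and so says nothing direct about this exchange; compound 3 differs from compound 1 and compound 2 in several places at once. Among the compounds with values here, no measured step therefore bears on the change. The expectation for compound 4 is a step of a 1.6-fold higher number from compound 3 to compound 4 (0.21 log units; within the scatter), small and uncertain in direction. Compound 4 is estimated at 15 nM, between 4 nM and 60 nM.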

Compound 4, half-maximal effective concentration: 513 nM
The estimate for compound 4 lay 34-fold (1.53 log units) below the measured number; measured number above the stated range.
By their numbers in this assay, from the lowest: compound 3; then compounds 2 and 1 (each within the scatter of the next); then compound 4.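

In this assay the aryl group on this saturated chain carbon bound to an aromatic carbon matters greatly: 4-methoxyphenyl in place of 2-methylphenyl gives a 55-fold higher number from compound 3 to compound 4 (1.74 log units; beyond the scatter) and so moves the number far beyond the scatter. Going by these compounds alone, the only earlier single step, made at a different chain carbon, stayed within the scatter. No measurement shown explains the size of this step. The compounds shown leave open whether losing 2-methylphenyl or gaining 4-methoxyphenyl accounts for it. An unsubstituted phenyl group at this place could help separate the two.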